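Cyclohexyl Ester in Place of Hexyl Ester

The compounds below may be only part of what the source reports. "The series", "measured", "known", "first", "only" and "open" are said of these compounds alone.

Among the measured compounds shown here, compound 2 `CCCCCCOC(=O)c1cc(NC(=O)c2cnc(Cl)nc2C(F)(F)F)cc(C(F)(F)F)c1` gives the lowest of the two numbers known so far: in an assay on Jurkat cells for inhibition of nuclear factor NF-kappa-B p105 subunit (Homo sapiens) (on this read-out lower numbers stand for stronger inhibition and higher numbers for weaker inhibition), compound 2 gives 620 nM, whereas compound 1 `NC(=O)c1cc(NC(=O)c2cnc(Cl)nc2C(F)(F)F)cc(C(F)(F)F)c1` gives 5000 nM in this assay. For the measured compounds named here, the only measured step, an 8.1-fold lower number from compound 1 to compound 2 (0.91 log units; beyond the scatter), concerns the exchange of amino for hexyloxy on the carbonyl carbon. Compound 3 `O=C(OC1CCCCC1)c1cc(NC(=O)c2cnc(Cl)nc2C(F)(F)F)cc(C(F)(F)F)c1` differs from compound 2 by cyclohexyl in place of hexyl on an oxygen next to a carbonyl group. Going by the values given here, no measured step bears on this exchange, so the expected step is a 1.0-fold lower number from compound 2 to compound 3 (0.01 log units; within the scatter), within the scatter. Compound 3 is therefore estimated at 600 nM, with a range from 200 nM to 2000 nM.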

Compound 3, half-maximal inhibitory concentration: 1800 nM
Beside the measured number, compound 3's estimate is 3.0-fold (0.48 log units) below it; low and high end bracket the measured number.
By their numbers in this assay, from the lowest: compound 2; then compound 3; then compound 1.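

In this assay, this position responds to the shape of the ester group as well as to the exchange of amino for an ester: with hexyl and cyclohexyl both counting six carbon atoms, the ring gives a weaker result (a 2.9-fold higher number from compound 2 to compound 3 (0.46 log units; beyond the scatter)). The cyclohexyl ester still keeps a clear advantage over the amino compound (a 2.8-fold lower number from compound 1 to compound 3 (0.44 log units; beyond the scatter)), so that advantage does not require an open chain. No evidence at hand explains the difference between ring and chain.

Going by these compounds, whether a shorter chain such as ethyl, or a smaller ring such as cyclopentyl, would match hexyl remains open. So does the effect of a carboxylic acid at this carbonyl carbon.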